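Lipophilicity of aryl ether quinazolinones: removing a ring

The source may report more compounds than this note shows. Statements on the series, on what has been measured and on what is new or still open speak of the compounds shown alone.

Measured so far in a physicochemical assay for lipophilicity, in phosphate buffer, measured as octanol-water partition; on this read-out higher numbers stand for higher lipophilicity and lower numbers for lower lipophilicity:
Compound 1 `CCCc1nc2ccccc2c(=O)n1/N=C/c1ccc(Oc2ccc(Cl)cc2)cc1` gives 5.78.
Compound 2 `Cc1nc2ccccc2c(=O)n1/N=C/c1ccc(Oc2ccc3ccccc3c2)cc1` gives 5.22.
Compound 3 `CCCc1nc2ccccc2c(=O)n1/N=C/c1ccc(Oc2ccc3ccccc3c2)cc1` gives 6.12.

Compound 2 stands lowest of the three in this assay; compound 1 is nearest, compound 3 furthest, and both steps from it are beyond the scatter, as a number 0.90 log units higher from compound 2 to compound 3 (beyond the scatter) shows for the chain. Compound 4 `Cc1nc2ccccc2c(=O)n1/N=C/c1ccc(Oc2ccccc2)cc1` differs from compound 2 by phenyl in place of naphthalen-2-yl on an oxygen on an aromatic ring. For the measured compounds named here, the one measured step at that position is a number 0.34 log units higher from compound 1 to compound 3 (beyond the scatter), which swapped a substituted single ring for the two-ring group; the reverse direction here removes the second ring and also lacks the chlorine that compound 1 carried. The step in this assay is therefore expected to be downward and larger than the step from compound 1 to compound 3, giving a number 1.02 log units lower from compound 2 to compound 4 (beyond the scatter) for compound 4. Compound 4 is estimated at 4.2, in the range 3.7 to 4.7.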

Compound 4, partition coefficient: 4.01
Compound 4: middle estimate off by 0.19 log units, on the high side, and the stated range covers the measured number.
By their numbers in this assay, from the lowest: compound 4; then compound 2; then compound 1; then compound 3.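

In this assay, for the compounds shown here, taking away the second ring at this position, on an oxygen on an aromatic ring, gives a number 1.21 log units lower from compound 2 to compound 4 (beyond the scatter), the first step here from the two-ring naphthalen-2-yl to a plain phenyl with no other substituent. This step, in which the group loses four carbons and gains no hydrogen-bond donors or acceptors, is printed as large, whereas a number 0.34 log units higher from compound 1 to compound 3 (beyond the scatter) is printed as modest, so the group on this oxygen can move the read-out further than the earlier pair showed. Nothing available accounts for the size of this step. The compounds shown leave open how a plain phenyl at this position would read with the longer chain of compound 3. They also leave open where an amine or a carboxylic acid on this ring would fall.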